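This account rests on a few compounds, and the source may have more. Where it says the series, first, only, none or still open, it means among the compounds named here.

In a physicochemical assay for lipophilicity, read by HPLC, at pH 7.5 (on this read-out lower numbers stand for lower lipophilicity and higher numbers for higher lipophilicity), compound 1 (`CC[C@@H](Nc1c(C#N)c(-c2ccc(-c3ccc(OC)cc3)cc2)nc2cnccc12)C(N)=O`) gives 2.7 and compound 2 (`CC[C@@H](Nc1c(C#N)c(-c2ccc(-c3cnccc3C)cc2)nc2cnccc12)C(N)=O`) gives 2 while compound 3 (`CCOc1ccccc1-c1ccc(-c2nc3cnccc3c(N[C@H](CC)C(N)=O)c2C#N)cc1`) gives 3 on the same shared core. The read-out runs a number 0.30 log units higher from compound 1 to compound 3 (within the scatter) so these two cannot be ordered. For the measured compounds named here, it runs a number 1.00 log units higher from compound 2 to compound 3 (beyond the scatter) and this is the one clear separation for compound 3 so far.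

Compound 4 (`CC[C@@H](Nc1c(C#N)c(-c2ccc(-c3cccc(Cl)c3)cc2)nc2cnccc12)C(N)=O`) carries 3-chlorophenyl in place of 2-ethoxyphenyl on an aromatic carbon of a six-membered aromatic ring of carbon only, para to a large group. Going by the values given here, no measured compound carries 3-chlorophenyl, so the evidence is indirect. Among the compounds with values here, the closest precedent is the exchange of one six-membered aromatic ring of carbon only for another, which ran a number 0.30 log units higher from compound 1 to compound 3 (within the scatter) in the measured pair. Within the data shown here, the larger steps, a number 0.70 log units lower from compound 1 to compound 2 (beyond the scatter) and a number 1.00 log units higher from compound 2 to compound 3 (beyond the scatter), both involve the 4-methylpyridin-3-yl of compound 2, a group that has no counterpart in this change, so they bear on it only weakly.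

The estimate is a number 0.10 log units higher from compound 3 to compound 4 (within the scatter) in this assay and so no step beyond the scatter is expected. Compound 4 is expected at 3.1 within an estimated range of 2.7 to 3.5 on this evidence.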

Compound 4, distribution coefficient: 3.1
The estimate for compound 4 equals the measured number at the digits printed, within the range that was stated.
By their numbers in this assay, from the lowest: compound 2; then compounds 1, 3 and 4 (each within the scatter of the next, the first and the last beyond it).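

Notes on the aromatic carbon para to a large group: in this assay, 3-chlorophenyl in place of 2-ethoxyphenyl gives a number 0.10 log units higher from compound 3 to compound 4 (within the scatter) and so does not separate the two groups, even though they differ in heavy atoms and 2-ethoxyphenyl carries a hydrogen-bond acceptor that 3-chlorophenyl lacks. 3-Chlorophenyl in place of 4-methoxyphenyl gives a number 0.40 log units higher from compound 1 to compound 4 (beyond the scatter) and is the first step beyond the scatter between two groups that each have a six-membered aromatic ring of carbon only, although compound 3 stays within the scatter of both compound 1 and compound 4. 3-Chlorophenyl in place of 4-methylpyridin-3-yl gives a number 1.10 log units higher from compound 2 to compound 4 (beyond the scatter) and so adds a third carbon-only ring group lying beyond the scatter of compound 2, which keeps the lowest number in the set.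

No measurement at hand accounts for any of these steps. Still open, on these data alone, is where a phenyl ring bearing an amine or a carboxylic acid, or a longer alkoxy chain than the ethoxy of compound 3, would fall at this position on the same shared core.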